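A few compounds are considered here, and "the series" means these few. Any claim that something is new, unique, unknown or untested is made for them only; others in the source may bear on it.

Compound 1 `C/N=C(/NC)Nc1nc(-c2ccc(OC)cc2)c(-c2ccc(OC)cc2)s1` gives 970 nM in a functional assay with Oryctolagus cuniculus as the target; a higher number here means a weaker inhibitor, a lower number a stronger inhibitor. For compound 2 `COc1ccc(-c2nc(/N=C(\N)[N+]3(C)CCCCC3)sc2-c2ccc(OC)cc2)cc1` this assay reports only a limit, > 1000 nM. Compound 3 `COc1ccc(-c2nc(/N=C(\N)N3CCOCC3)sc2-c2ccc(OC)cc2)cc1` likewise stands only at a limit in this assay, < 1000 nM, so its position on the numbers is open. The measured steps at the same aromatic carbon are an at least 1.0-fold higher number from compound 1 to compound 2 (0.01 log units; that floor lies within the scatter) and a step that the limit leaves unreadable from compound 1 to compound 3, with a number no higher from compound 2 to compound 3 (the limit leaves the size open) between the two limits; none reaches a readable size. Compound 4 `COc1ccc(-c2nc(C(=O)N3CCOCC3)sc2-c2ccc(OC)cc2)cc1` differs from compound 3 by a group of 8 heavy atoms (5 carbon, 1 nitrogen, 2 oxygen; one six-membered non-aromatic ring with 2 hetero atoms) in place of a group of 9 heavy atoms (5 carbon, 3 nitrogen, 1 oxygen; one six-membered non-aromatic ring with 2 hetero atoms), on an aromatic carbon. Within the data shown here, no measured step exchanges this kind of group, so no direction is read from the series; compound 4 is expected near 1500 nM, within 300 nM to 8000 nM. The step this estimate implies is an at least 1.5-fold higher number from compound 3 to compound 4 (0.17 log units; that floor lies within the scatter).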

Compound 4, half-maximal inhibitory concentration: < 10 nM
Compound 4: only a limit was reported; the forecaster's own chance of this, stated with the estimate: 45%; middle value at least 150-fold (2.17 log units) from the limit.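

Among these compounds, although compound 4 is known only by a limit, (morpholin-4-yl)carbonyl on this aromatic carbon gives the first readable steps in this assay: an at least 100-fold lower number from compound 2 to compound 4 (2.00 log units; beyond the scatter) and an at least 97-fold lower number from compound 1 to compound 4 (1.98 log units; beyond the scatter). The step from compound 3, which keeps the same ring, cannot be read, nor can the other steps between limits, so the share of the carbonyl alone has no size. Nothing shown gives a cause for these steps.

On these data alone, how far the carbonyl and the ring each count stays open. Piperidin-1-ylcarbonyl or a carboxylic acid on this carbon would separate the two.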